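Carbamoyl to Benzoyl: Expecting the Next Number

This account rests on a few compounds, and the source may have more. Where it says the series, first, only, none or still open, it means among the compounds named here.

Measured so far:
Compound 1 `N#C/C(=C\N1CCN(C(=O)c2ccco2)C1=S)C(=O)Nc1ccc(Cl)cc1` gives 19900 nM in a functional assay on NCI-H460 cells (Homo sapiens) for inhibition, read by sulforhodamine B assay, with a stated time of 48 h; on this read-out higher numbers stand for weaker inhibition of growth and lower numbers for stronger inhibition of growth.
Compound 2 `N#C/C(=C\N1CCN(C(=O)c2ccco2)C1=S)C(N)=O` gives 4000 nM in this assay.

Going by the values given here, of these two numbers, compound 2 stands lowest, with compound 1 as its only neighbour at a higher number. Compound 3 `N#C/C(=C\N1CCN(C(=O)c2ccco2)C1=S)C(=O)c1ccccc1` is not yet measured; against compound 2 it shows (phenyl in place of amino on a carbonyl carbon). Among the compounds with values here, one measured step bears on this: a 5.0-fold lower number from compound 1 to compound 2 (0.70 log units; beyond the scatter), where taking the 4-chlorophenyl off the amide-type nitrogen lowered the number. Compound 3 again places a phenyl on the carbonyl carbon, so a modest rise in the number is expected, a 2.0-fold higher number from compound 2 to compound 3 (0.30 log units; within the scatter). The estimate for compound 3 is 8000 nM, ranging from 3000 nM to 25000 nM.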

Compound 3, concentration for 50% growth inhibition: 9500 nM
Estimate against measurement, compound 3: 1.2-fold (0.07 log units) below; measured number inside the range.
By their numbers in this assay, from the lowest: compound 2; then compound 3; then compound 1.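

Putting phenyl in place of amino on the carbonyl carbon gives a 2.4-fold higher number from compound 2 to compound 3 (0.38 log units; beyond the scatter), so in this assay compound 2 remains lowest, with both ring-bearing compounds above it. Phenyl in place of (4-chlorophenyl)amino gives a 2.1-fold lower number from compound 1 to compound 3 (0.32 log units; beyond the scatter), showing that the two ring-bearing groups on this carbon are not interchangeable. No measurement here explains either step.

The compounds shown cannot separate the contribution of the chlorine from that of the nitrogen link. On these data alone, how a methyl group or a hydroxyl group on this carbonyl carbon would compare also remains open.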